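Anilide ring substitution in the shared-core series

This account rests on a few compounds, and the source may have more. Where it says the series, first, only, none or still open, it means among the compounds named here.

Measured so far:
compound 1 `O=C(CCc1cccc2c1B(O)OC2)Nc1ccccc1`: 230 nM
compound 2 `COc1ccc(NC(=O)CCc2cccc3c2B(O)OC3)cc1`: 850 nM
compound 3 `CC(C)(C)OC(=O)Nc1ccc(NC(=O)CCc2cccc3c2B(O)OC3)cc1`: 29000 nM

All three share one core and differ only on the anilide ring, read in a functional assay on MDA-MB-231 cells (Homo sapiens) for antiproliferative activity, read by MTT assay, with a stated time of 72 h; on this read-out lower numbers stand for stronger inhibition and higher numbers for weaker inhibition. Compound 1 gives the lowest number of the three in this assay; its nearest neighbour is compound 2 at a 3.7-fold higher number from compound 1 to compound 2 (0.57 log units; beyond the scatter), its furthest is compound 3 at a 130-fold higher number from compound 1 to compound 3 (2.10 log units; beyond the scatter), and between the two substituted compounds the step is a 34-fold higher number from compound 2 to compound 3 (1.53 log units; beyond the scatter).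

Compound 4 `CSc1ccc(-c2cccc(NC(=O)CCc3cccc4c3B(O)OC4)c2)cc1` is not yet measured. Relative to compound 1 it carries 4-(methylsulfanyl)phenyl in place of hydrogen on an aromatic carbon.

Both measured steps that start from compound 1 add a group to the same ring and both raise the number, modestly with methoxy and strongly with (tert-butoxycarbonyl)amino. The entering group in compound 4 is large and sits at a different place on that ring, so neither step is a direct match, but nothing in the set shows an added group lowering the number. A step upward beyond the scatter is therefore expected for compound 4, closer to the modest step than to the large one, estimated at a 3.9-fold higher number from compound 1 to compound 4 (0.59 log units; beyond the scatter).

Compound 4 is estimated at 900 nM in this assay, within 200 nM to 4500 nM.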

Compound 4, half-maximal inhibitory concentration: 140 nM
Compound 4: middle estimate off by 6.4-fold (0.81 log units), on the high side; the whole stated range lies above it.
By their numbers in this assay, from the lowest: compounds 4 and 1 (each within the scatter of the next); then compound 2; then compound 3.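

In this assay, 4-(methylsulfanyl)phenyl on an aromatic carbon meta to a large group gives a 1.6-fold lower number from compound 1 to compound 4 (0.22 log units; within the scatter), so compound 4 and compound 1 cannot be told apart at this position. The earlier steps shown here showed only higher numbers after a group was added to the anilide ring, namely a 3.7-fold higher number from compound 1 to compound 2 (0.57 log units; beyond the scatter) with methoxy and a 130-fold higher number from compound 1 to compound 3 (2.10 log units; beyond the scatter) with (tert-butoxycarbonyl)amino; compound 4 now shows that an entering group of 8 heavy atoms can leave the number within the scatter, and compound 2 and compound 3 remain the compounds that go the other way. The data shown give no measurement that explains this result.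

Going by these compounds, because the entering group and its place on the ring differ together across these compounds, it remains open whether the result belongs to this position or to 4-(methylsulfanyl)phenyl itself, and methoxy or (tert-butoxycarbonyl)amino at this same position would separate the two. Also open, on these data alone, is whether an unsubstituted phenyl, or a phenyl carrying an amine or a carboxylic acid in place of methylsulfanyl, would stay within the scatter of compound 1.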